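The compounds below may be only part of what the source reports. "The series", "measured", "known", "first", "only" and "open" are said of these compounds alone.

In a functional assay on KB cells (Homo sapiens) for antiproliferative activity, read by MTT assay, with a stated time of 48 h (on this read-out lower numbers stand for stronger inhibition and higher numbers for weaker inhibition), compound 1 (`Cn1cc(C2=C(c3nn(CCCN4CCCCC4)c4ncccc34)C(=O)N(c3ccc(Cl)cc3)C2=O)c2ccccc21`) gives > 100000 nM, which is a limit of the assay and not a number. Among the compounds with values here, compound 2 (`Cn1cc(C2=C(c3nn(CCCN4CCCCC4)c4ncccc34)C(=O)N(c3cccc4ccccc34)C2=O)c2ccccc21`) gives 13400 nM, the only true number so far. Within the data shown here, the single measured step is an at least 7.4-fold lower number from compound 1 to compound 2 (0.87 log units; beyond the scatter), and it exchanges 4-chlorophenyl for naphthalen-1-yl on the amide-type nitrogen in a ring. Compound 3 (`Cn1cc(C2=C(c3nn(CCCN4CCCCC4)c4ncccc34)C(=O)N(c3ccccn3)C2=O)c2ccccc21`) changes the same place: pyridin-2-yl in place of naphthalen-1-yl on an amide-type nitrogen in a ring. Here pyridin-2-yl replaces naphthalen-1-yl, so the two aromatic rings of carbon only give way to one six-membered aromatic ring with a hetero atom. Among the measured compounds shown here, the step of an at least 7.4-fold lower number from compound 1 to compound 2 (0.87 log units; beyond the scatter) is the only evidence bearing on this place, and it is a thin basis, but it suggests that leaving naphthalen-1-yl for a group with one ring should raise the number. The expected change is a 3.0-fold higher number from compound 2 to compound 3 (0.47 log units; beyond the scatter), towards weaker inhibition in this assay. For compound 3 the estimated value is 40000 nM, with an expected range of 9000 nM to 100000 nM.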

Compound 3, half-maximal inhibitory concentration: > 100000 nM
Compound 3: no number, only a limit (the forecaster's own chance of this, stated with the estimate: 35%); middle value at least 2.5-fold (0.39 log units) away from the limit.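

Compound 3 gives > 100000 nM in this assay, which is a limit of the assay and not a number. Exchanging naphthalen-1-yl for pyridin-2-yl on the amide-type nitrogen in a ring gives an at least 7.4-fold higher number from compound 2 to compound 3 (0.87 log units; beyond the scatter), so a second single-ring group now joins 4-chlorophenyl in losing the measurable activity seen with naphthalen-1-yl, and among these three compounds only compound 2 has a true number. The step between compound 1 and compound 3 cannot be read, and 4-chlorophenyl and pyridin-2-yl cannot be ordered against each other, because both compounds stop at the same limit: the limit of > 100000 nM in this assay, at which 2 of the 3 values shown sit.

The exchange in compound 3 removes a ring of carbon only and brings in a ring nitrogen at the same time, so the compounds shown do not tell which of these two changes matters, a question that a quinolin-8-yl group, with two rings and a ring nitrogen, or a plain phenyl group could help to separate. On these data alone, it also stays open whether naphthalen-2-yl, which attaches the same two rings differently, would keep a measurable value in this assay.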